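A few compounds are considered here, and "the series" means these few. Any claim that something is new, unique, unknown or untested is made for them only; others in the source may bear on it.

Measured so far in an assay for binding affinity to dual specificity mitogen-activated protein kinase kinase 4 (Homo sapiens), read by KINOMEscan, tested at 100 nM; on this read-out lower numbers stand for a stronger effect and higher numbers for a weaker effect at the one concentration tested:
- compound 1 `CCCS(=O)(=O)Nc1ccc(F)c(C(=O)c2n[nH]c3ncc(-c4cccc(O)c4)cc23)c1F` gives 2.2%
- compound 2 `CCCS(=O)(=O)Nc1ccc(F)c(C(=O)c2n[nH]c3ncc(-c4ccc(OC)cc4Cl)cc23)c1F` gives 5.3%
- compound 3 `CCCS(=O)(=O)Nc1ccc(F)c(C(=O)c2n[nH]c3ncc(-c4cccc(C(F)(F)F)c4)cc23)c1F` gives 57%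

Compound 1 has the lowest number of the three; compound 2 sits within the scatter of it (a number 3.1 percentage points higher from compound 1 to compound 2 (within the scatter)), while compound 3 lies far beyond it (a number 54.8 percentage points higher from compound 1 to compound 3 (beyond the scatter)). Compound 4 `CCCS(=O)(=O)Nc1ccc(F)c(C(=O)c2n[nH]c3ncc(-c4ccc([N+](=O)[O-])cc4)cc23)c1F` differs from compound 1 by 4-nitrophenyl in place of 3-hydroxyphenyl on an aromatic carbon. For the measured compounds named here, two measured steps bear on this: swapping the 3-hydroxyphenyl for another substituted phenyl left the number unchanged within the scatter, whereas removing the hydroxy donor for trifluoromethyl raised it sharply. The 4-nitrophenyl of compound 4 also carries no donor, so a rise in this assay is expected, of uncertain size. Compound 4 is therefore estimated at 30%, within 5% to 75%. That estimate means a step of a number 27.8 percentage points higher from compound 1 to compound 4 (beyond the scatter).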

Compound 4, a percentage reported as activity, at one concentration (the size of the read-out at that concentration, not a potency): 4.2%
Beside the measured number, compound 4's estimate is 25.8 percentage points above it; the measured number lies below the stated range.
By their numbers in this assay, from the lowest: compounds 1, 4 and 2 (each within the scatter of the next); then compound 3.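

In this assay the 4-nitrophenyl group, with 0 hydrogen-bond donors, stays level with the 3-hydroxyphenyl group (a number 2 percentage points higher from compound 1 to compound 4 (within the scatter)) and with the 2-chloro-4-methoxyphenyl group (a number 1.1 percentage points lower from compound 2 to compound 4 (within the scatter)). The hydroxy group is therefore not needed for a low number at this position, and compound 3 alone stands apart among the four (a number 52.8 percentage points lower from compound 3 to compound 4 (beyond the scatter)). No evidence on the reason for this gap is available.

From the compounds shown here alone, whether 3-nitrophenyl or 4-(trifluoromethyl)phenyl would stay low remains open, leaving the roles of group and ring position in compound 3 unseparated. Going by these compounds, an amine or a carboxylic acid on the phenyl ring also remains untested here.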